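Three Measured Ureas and a Fluoro Analogue Awaiting Measurement

The source may report more compounds than this note shows. Statements on the series, on what has been measured and on what is new or still open speak of the compounds shown alone.

Compound 1, `Cc1cc(NC(=O)Nc2cccc(C(N)=O)c2)c2ccccc2n1`, in an ADME assay on Raji cells (Homo sapiens) for cytotoxicity, with a stated time of 72 h (on this read-out lower numbers stand for an effect already at smaller amounts and higher numbers for an effect only at larger amounts of compound), gives only a limit, > 25000 nM.
Compound 2, `Cc1cc(NC(=O)Nc2cccc3nsnc23)c2ccccc2n1`, in this assay also gives only a limit, > 25000 nM.
Compound 3, `Cc1cc(NC(=O)Nc2ccc(OC(F)(F)F)cc2)c2ccccc2n1`, in this assay gives 10000 nM.

Compound 1 therefore does not stand at a number in this assay: its value is a limit of the assay, and the limit of > 25000 nM in this assay, at which 2 of the 3 values shown sit, shows that compound 2 sits at the same limit. Only compound 3 yields a number, and that number cannot be compared with the limits of compound 1 and compound 2 as a step of known size.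

Compound 4, `Cc1cc(NC(=O)Nc2cccc(F)c2)c2ccccc2n1`, differs from compound 1 in one place: fluoro in place of carbamoyl on an aromatic carbon. For the measured compounds named here, no step between measured compounds tells how such a change moves the read-out, so the expectation rests on the three values shown. Compound 1 sits at a limit in this assay. Compound 3 gives 10000 nM. Compound 4 is expected to land within the scatter of compound 3 or somewhat above it. The step of an at least 1.2-fold lower number from compound 1 to compound 4 (0.09 log units; that floor lies within the scatter) is therefore expected to be small, if any. For compound 4 the estimate is 20000 nM, with a range from 8000 nM to 50000 nM.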

Compound 4, half-maximal effective concentration: > 25000 nM
Compound 4 was reported as a limit; the forecaster's own chance of this, stated with the estimate: 55%; middle value at least 1.2-fold (0.09 log units) away from the limit.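

Compound 1 and compound 4 both stand only at a limit in this assay, so no step between them can be read: the limit of > 25000 nM in this assay, at which 3 of the 4 values shown sit.

The compounds shown leave open how far, if at all, fluoro in place of carbamoyl on an aromatic carbon moves this read-out.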